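The source may hold more compounds than are shown below. What is called first, only, known or untested is meant among the compounds shown, and "the series" means these compounds.

The measured compounds and their numbers are these:

Compound 1, `O=C(Nc1ccc(Cl)c(-c2nc3ccccc3[nH]2)c1)c1ccc(F)cc1`, gives 251 nM in a functional assay on Shh Light II cells for inhibition of Sonic hedgehog protein (Mus musculus), read by reporter gene assay, with a stated time of 48 h, in the presence of a further agent that is not named here; on this read-out lower numbers stand for stronger inhibition and higher numbers for weaker inhibition.
Compound 2, `CN(C)c1ccc(C(=O)Nc2ccc(Cl)c(-c3nc4ccccc4[nH]3)c2)cc1`, gives 190 nM in this assay.
Compound 3, `N#Cc1ccc(C(=O)Nc2ccc(Cl)c(-c3nc4ccccc4[nH]3)c2)cc1`, gives 185 nM in this assay.

Compound 3 stands at the lowest of the three numbers, yet its distance to the others is small: the step of a 1.4-fold lower number from compound 1 to compound 3 (0.13 log units; within the scatter) and the step of a 1.0-fold lower number from compound 2 to compound 3 (0.01 log units; within the scatter) both lie within the scatter, and so does a 1.3-fold lower number from compound 1 to compound 2 (0.12 log units; within the scatter). The three compounds therefore cannot be told apart on this read-out.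

Compound 4, `COc1ccc(C(=O)Nc2ccc(Cl)c(-c3nc4ccccc4[nH]3)c2)cc1`, has not yet been measured. It differs from compound 3 in one place: methoxy in place of cyano on an aromatic carbon. Going by the values given here, the steps that bear on this change are those in which the same position on the shared core carried fluoro, dimethylamino or cyano, and none of them moved the number beyond the scatter. On that basis the group at this position appears to leave this assay largely untouched across the compounds shown, and no step beyond the scatter is expected for compound 4 either. The expected step is a 1.1-fold higher number from compound 3 to compound 4 (0.06 log units; within the scatter). Compound 4 is estimated at 210 nM, with a range from 100 nM to 450 nM.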

Compound 4, half-maximal inhibitory concentration: 117 nM
Compound 4: middle estimate off by 1.8-fold (0.25 log units), on the high side; measured number inside the range.
By their numbers in this assay, from the lowest: compounds 4, 3, 2 and 1 (each within the scatter of the next, the first and the last beyond it).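

In this assay, putting methoxy on this aromatic carbon stays within the scatter against cyano, with a 1.6-fold lower number from compound 3 to compound 4 (0.20 log units; within the scatter), and against dimethylamino, with a 1.6-fold lower number from compound 2 to compound 4 (0.21 log units; within the scatter). Going by these compounds alone, the first step at this position to lie beyond the scatter is a modest one, a 2.1-fold lower number from compound 1 to compound 4 (0.33 log units; beyond the scatter), so the group para to a large group is not wholly without bearing on the number, although only the fluoro and methoxy compounds are separated, and the cyano and dimethylamino compounds cannot be told apart from either methoxy or each other. No measurement at hand accounts for the gap between the fluoro and methoxy compounds.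

The compounds shown leave open whether a carboxylic acid, a primary amine or a longer chain such as butoxy on this aromatic carbon would move the number further than methoxy does, in either direction. They also leave open whether the modest step from fluoro to methoxy would be repeated with a hydroxy group here, or with methoxy at another place on the same six-membered aromatic ring.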